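Notes on the aryl group at the chain carbon

The compounds below may be only part of what the source reports. "The series", "measured", "known", "first", "only" and "open" are said of these compounds alone.

Compound 3 `CC(C)C[C@@H]1C(=O)N[C@H](C2Cc3ccccc3C2)C(=O)N1[C@@H](C(=O)NC(C)C)c1cccs1` gives 6.31 nM in an assay on isolated protein for binding affinity to Oxytocin receptor (Homo sapiens) (a lower number here means a stronger inhibitor, a higher number a weaker inhibitor), the highest of the three numbers recorded in the series. Compound 1 `Cc1cc([C@H](C(=O)NC(C)C)N2C(=O)[C@@H](C3Cc4ccccc4C3)NC(=O)[C@H]2CC(C)C)oc1C` gives 1.26 nM, and compound 2 `CC(C)C[C@@H]1C(=O)N[C@H](C2Cc3ccccc3C2)C(=O)N1[C@@H](C(=O)NC(C)C)c1ccc(Br)o1` gives 0.794 nM. Compound 4 `CC(C)C[C@@H]1C(=O)N[C@H](C2Cc3ccccc3C2)C(=O)N1[C@@H](C(=O)NC(C)C)c1coc(C(F)(F)F)n1` differs from compound 3 by a group of 9 heavy atoms (4 carbon, 1 nitrogen, 1 oxygen, 3 fluorine; one five-membered aromatic ring with 2 hetero atoms) in place of a group of 5 heavy atoms (4 carbon, 1 sulfur; one five-membered aromatic ring with 1 hetero atom), on a saturated chain carbon bound to an amide-type nitrogen in a ring and a carbonyl carbon. The measured steps at this position are a 5.0-fold higher number from compound 1 to compound 3 (0.70 log units; beyond the scatter) and a 7.9-fold higher number from compound 2 to compound 3 (0.90 log units; beyond the scatter), both beyond the scatter, whereas a 1.6-fold lower number from compound 1 to compound 2 (0.20 log units; within the scatter) lies within it. Going by the values given here, no measured step involves the group that enters. The two steps show that thiophen-2-yl gave higher numbers than either furan, so a lower number is expected for compound 4, with uncertain size. The expected step is a 2.1-fold lower number from compound 3 to compound 4 (0.32 log units; beyond the scatter). Compound 4 is estimated at 3 nM, within 0.8 nM to 12 nM.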

Compound 4, inhibition constant: 0.159 nM
For compound 4 the middle estimate is 19-fold (1.28 log units) above the measured one; the measured number lies below the stated range.
By their numbers in this assay, from the lowest: compound 4; then compounds 2 and 1 (each within the scatter of the next); then compound 3.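

In this assay the entering group of 9 heavy atoms, with 2 hetero atoms in its ring, gives a lower number than all three earlier groups: a 40-fold lower number from compound 3 to compound 4 (1.60 log units; beyond the scatter), a 5.0-fold lower number from compound 2 to compound 4 (0.70 log units; beyond the scatter), and a 7.9-fold lower number from compound 1 to compound 4 (0.90 log units; beyond the scatter). This position therefore allows a wider range of numbers than the furans and thiophen-2-yl showed, and a lower number than either furan gave. No measurement here accounts for this gain.

The compounds shown do not separate the contribution of the ring from that of its trifluoromethyl group. From the compounds shown here alone, how a phenyl ring, or an amine or carboxylic acid on the ring, would fare at this chain carbon also remains open.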